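The source may report more compounds than this note shows. Statements on the series, on what has been measured and on what is new or still open speak of the compounds shown alone.

Measured so far:
compound 1 `COc1cc(N2C(N)=C(C#N)C(c3c(O)ccc4ccccc34)C3=C2CC(C)(C)CC3=O)cc(OC)c1OC`: 90%
compound 2 `COc1ccccc1C1C(C#N)=C(N)N(c2cc(OC)c(OC)c(OC)c2)C2=C1C(=O)CC(C)(C)C2`: 100%

In a functional assay on Ehrlich cells (Mus musculus) for cytotoxicity, tested at 100 ug/mL (a higher number here means a stronger effect of the compound at the concentration tested, a lower number a weaker effect), compound 1 has the smaller of the two numbers, yet the step of a number 10 percentage points higher from compound 1 to compound 2 (within the scatter) lies within the scatter, so the two compounds are not told apart. Compound 3 `COc1cc(N2C(N)=C(C#N)C(c3ccc(C)o3)C3=C2CC(C)(C)CC3=O)cc(OC)c1OC` differs from compound 1 by 5-methylfuran-2-yl in place of 2-hydroxynaphthalen-1-yl on a saturated ring carbon. For the measured compounds named here, the one measured step that bears on this, a number 10 percentage points higher from compound 1 to compound 2 (within the scatter), also exchanged the same group on the same saturated ring carbon and stayed within the scatter. For compound 3 a step of no change at the digits printed from compound 1 to compound 3 (within the scatter) is therefore expected, none beyond the scatter. Compound 3 is estimated at 90%, between 72% and 100%.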

Compound 3, a percentage reported as activity, at one concentration (the size of the read-out at that concentration, not a potency): 50%
For compound 3 the middle estimate is 40 percentage points above the measured one, outside the stated range (below it).
By their numbers in this assay, from the lowest: compound 3; then compounds 1 and 2 (each within the scatter of the next).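

In this assay, this saturated ring carbon turns out to be sensitive to the group it carries: 5-methylfuran-2-yl gives a number 40 percentage points lower from compound 1 to compound 3 (beyond the scatter) and a number 50 percentage points lower from compound 2 to compound 3 (beyond the scatter). The earlier exchange between the two six-membered aromatic groups had not told the compounds apart, so the position does not treat every aromatic group alike. Nothing available here explains this drop. The compounds shown leave open whether the lower number goes with the methyl or with the five-membered ring, which a plain furan-2-yl could separate. Going by these compounds, how a phenyl carrying an amine would read at this carbon also stays open.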